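Replacing 1,3-benzothiazol-2-yl with 6-chloropyridin-2-yl

This account rests on a few compounds, and the source may have more. Where it says the series, first, only, none or still open, it means among the compounds named here.

Three compounds share one core and differ only in the group on a saturated chain carbon bound to an oxygen on an aromatic ring. In a functional assay for inhibition, with Homo sapiens as the target (on this read-out lower numbers stand for stronger inhibition and higher numbers for weaker inhibition), compound 1 `CC(C)(C)Sc1c(CC(C)(C)C(=O)O)n(Cc2ccc(Cl)cc2)c2ccc(OCc3ccc4cc(F)ccc4n3)cc12` gives 2 nM, compound 2 `CC(C)(C)Sc1c(CC(C)(C)C(=O)O)n(Cc2ccc(Cl)cc2)c2ccc(OCc3cc4ccccc4cn3)cc12` gives 3 nM and compound 3 `CC(C)(C)Sc1c(CC(C)(C)C(=O)O)n(Cc2ccc(Cl)cc2)c2ccc(OCc3nc4ccccc4s3)cc12` gives 3 nM. Compound 3 thus stands level with compound 2, and all three lie within the scatter of one another.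

The next compound, compound 4 `CC(C)(C)Sc1c(CC(C)(C)C(=O)O)n(Cc2ccc(Cl)cc2)c2ccc(OCc3cccc(Cl)n3)cc12`, keeps everything except that group: 6-chloropyridin-2-yl in place of 1,3-benzothiazol-2-yl on a saturated chain carbon bound to an oxygen on an aromatic ring. Within the data shown here, three measured steps bear on this exchange, since each swaps a group at the same place: a 1.5-fold higher number from compound 1 to compound 2 (0.18 log units; within the scatter), a 1.5-fold higher number from compound 1 to compound 3 (0.18 log units; within the scatter) and no change at the digits printed from compound 2 to compound 3 (within the scatter). None of them goes beyond the scatter in this assay, so the three groups tried cannot be told apart. Among the measured compounds shown here, no measured compound carries 6-chloropyridin-2-yl, however, and the entering group holds only one six-membered aromatic ring with 1 hetero atom, so the data do not test this exchange directly. A slightly higher number is expected, a 1.7-fold higher number from compound 3 to compound 4 (0.22 log units; within the scatter), with no clear step beyond the scatter. The estimated value for compound 4 is 5 nM, with an expected range from 2 nM to 15 nM.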

Compound 4, half-maximal inhibitory concentration: 3 nM
For compound 4 the middle estimate is 1.7-fold (0.22 log units) above the measured one, within the range that was stated.
By their numbers in this assay, from the lowest: compounds 1, 2, 3 and 4 (each within the scatter of the next).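

Among these compounds, compound 4 is the first in this set with only one aromatic ring in this position, a six-membered ring with 1 hetero atom, whereas 1,3-benzothiazol-2-yl brings a fused pair of rings. Even so, in this assay the exchange gives no change at the digits printed from compound 3 to compound 4 (within the scatter), the comparison with isoquinolin-3-yl gives no change at the digits printed from compound 2 to compound 4 (within the scatter), and the comparison with 6-fluoroquinolin-2-yl gives a 1.5-fold higher number from compound 1 to compound 4 (0.18 log units; within the scatter), so a second fused ring is not needed to stay in this low range on a saturated chain carbon bound to an oxygen on an aromatic ring. No measurement is available to explain why these four groups cannot be told apart.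

Still open, going by these compounds, is what the chlorine contributes, which a plain pyridin-2-yl group would test, and whether the ring nitrogen matters, which a 3-chlorophenyl group would address. Among the compounds shown here, also open is how far this tolerance extends, since a small methyl group or an amine-bearing chain in the same place might show the first step beyond the scatter.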